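The source may hold more compounds than are shown below. What is called first, only, known or untested is meant among the compounds shown, and "the series" means these compounds.

Of the compounds shown here, three built on a shared core have been measured in an assay on isolated protein for inhibition of Gonadotropin-releasing hormone receptor (Homo sapiens); on this read-out lower numbers stand for stronger inhibition and higher numbers for weaker inhibition. Compound 1 `COc1ccc([N+](=O)[O-])cc1CSc1nc2cc(NC(=O)NC(C)(C)C)ccc2n1Cc1ccccn1` gives 43 nM in this assay, compound 2 `COc1ccc([N+](=O)[O-])cc1CSc1nc2cc(NC(=O)OC(C)(C)C)ccc2n1C(C)C` gives 880 nM, and compound 3 `CCCn1c(SCc2cc([N+](=O)[O-])ccc2OC)nc2cc(NC(=O)NC(C)(C)C)cc(C(=O)N(C)C)c21` gives 270 nM. Among these three numbers compound 3 stands second highest: compound 2 sits at a higher number, a gap beyond the scatter, and compound 1 sits at a lower number, a gap that is also beyond the scatter. No two of the measured compounds differ in only one place, so the measured numbers do not show what any single change does.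

Compound 4 `CCCn1c(SCc2cc([N+](=O)[O-])ccc2OC)nc2cc(NC(=O)NC(C)(C)C)cc(C(=O)NCCCN(C)C)c21` has not yet been measured in this assay. It differs from compound 3 in one place: (3-(dimethylamino)propyl)amino in place of dimethylamino on a carbonyl carbon. The carbonyl itself stays where it was; only the group on its nitrogen grows from a short one into a longer chain ending in the same kind of nitrogen. Going by the values given here, with no guiding step among the measured compounds, the expected step of a 1.4-fold lower number from compound 3 to compound 4 (0.13 log units; within the scatter) is small, roughly within the scatter, and in no firm direction. Compound 4 is therefore expected to give about 200 nM, within a range from 60 nM to 700 nM.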

Compound 4, half-maximal inhibitory concentration: 170 nM
Beside the measured number, compound 4's estimate is 1.2-fold (0.07 log units) above it; low and high end bracket the measured number.
By their numbers in this assay, from the lowest: compound 1; then compounds 4 and 3 (each within the scatter of the next); then compound 2.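

Going by these compounds alone, this is the first pair in the set that differs in only one place. In this assay, replacing dimethylamino with (3-(dimethylamino)propyl)amino on a carbonyl carbon gives a 1.6-fold lower number from compound 3 to compound 4 (0.20 log units; within the scatter) and so leaves the two compounds indistinguishable on this read-out. The position therefore takes the longer chain, with its amide hydrogen and its second nitrogen, with no change in the number that stands out from the scatter, although no measurement here explains why that is so.

From the compounds shown here alone, it remains open whether the same holds for other groups on this carbonyl carbon, such as a shorter (2-(dimethylamino)ethyl)amino chain, a chain ending in a carboxylic acid, or a morpholine ring, so one tolerated swap does not yet describe the position as a whole. Compound 1, which has no carbonyl group at this place, also differs from compound 3 in other places, so what the carbamoyl group itself adds to the number cannot be read from the compounds shown.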